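The source may hold more compounds than are shown below. What is called first, only, known or untested is meant among the compounds shown, and "the series" means these compounds.

Compound 1 `N#CC1=C(N)Oc2c(c3nc4ccccc4nc3c3ccccc23)C12C(=O)N(Cc1cnnn1-c1ccccc1Cl)c1ccccc12` was examined in a functional assay on HCT-116 cells (Homo sapiens) for antiproliferative activity, read by MTT assay, with a stated time of 48 h; a lower number here means a stronger inhibitor, a higher number a weaker inhibitor. In this assay compound 1 reaches only a limit of the assay, > 50000 nM. Within the data shown here, its one measured neighbour is compound 2 `CCOc1ccc(-n2nncc2CN2C(=O)C3(C(C#N)=C(N)Oc4c3c3nc5ccccc5nc3c3ccccc43)c3ccccc32)cc1`, which differs from it by a single exchange on an aromatic nitrogen. In this assay compound 2 likewise gives only a limit of the assay, > 50000 nM. The step that the two limits leave unreadable from compound 1 to compound 2 therefore cannot be read, because the limit of > 50000 nM in this assay, at which 2 of the 2 values shown sit, is where both values sit. The unmeasured compound 3 `N#CC1=C(N)Oc2c(c3nc4ccccc4nc3c3ccccc23)C12C(=O)N(Cc1cnnn1-c1cccc(S(N)(=O)=O)c1)c1ccccc12` departs from compound 1 by 3-sulfamoylphenyl in place of 2-chlorophenyl on an aromatic nitrogen. Among the measured compounds shown here, the only measured step at the same aromatic nitrogen, the one to compound 2, has no readable size, so nothing among the measured compounds points to a change beyond the scatter in either direction. Compound 3 is therefore expected to remain at the limit, with an expected step of a number no higher from compound 1 to compound 3 (the limit leaves the size open) that is little more than a guess. Compound 3 is estimated at 50000 nM, in the range 20000 nM to 100000 nM.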

Compound 3, half-maximal inhibitory concentration: 11300 nM
For compound 3 the middle estimate is 4.4-fold (0.65 log units) above the measured one; the whole stated range lies above it.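

Until this result, the aryl group on this aromatic nitrogen had shown no readable effect in this assay, and the change from 2-chlorophenyl to 3-sulfamoylphenyl now gives an at least 4.4-fold lower number from compound 1 to compound 3 (0.64 log units; beyond the scatter), so this position does respond to what it carries. The change from 4-ethoxyphenyl to 3-sulfamoylphenyl gives an at least 4.4-fold lower number from compound 2 to compound 3 (0.64 log units; beyond the scatter), so the same entering group yields a measurable value from either of the two groups it replaces, on an otherwise unchanged core. Both steps give only a smallest size, and how much larger each one is stays open: the limit of > 50000 nM in this assay, at which 2 of the 3 values shown sit.

The step between compound 1 and compound 2 cannot be read, so the compounds shown do not order 2-chlorophenyl against 4-ethoxyphenyl, and they rest the change on a single entering group. Whether the sulfamoyl group itself matters remains open, since the compounds shown do not tell how a phenyl ring carrying a carboxylic acid or an amine in its place would behave on this nitrogen, or how a plain phenyl would.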